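The source may report more compounds than this note shows. Statements on the series, on what has been measured and on what is new or still open speak of the compounds shown alone.

Measured so far in an assay on isolated protein for displacement of a labelled ligand from growth hormone secretagogue receptor type 1 (Homo sapiens), with a stated time of 1 h; on this read-out lower numbers stand for stronger inhibition and higher numbers for weaker inhibition:

Compound 1, `COC(=O)C(c1ccccc1)n1nnnc1[C@@H](COCc1ccccc1)NC(=O)C(C)(C)N`, gives 470 nM.
Compound 2, `CC(C)(N)C(=O)N[C@H](COCc1ccccc1)c1nnnn1CCCCC#N`, gives 3120 nM.
Compound 3, `COC(=O)C(c1ccccc1)n1nnc([C@@H](COCc2ccccc2)NC(=O)C(C)(C)N)n1`, gives > 5000 nM, which is a limit of the assay and not a number.

Compound 4, `CC(C)(N)C(=O)N[C@H](COCc1ccccc1)c1nnn(CCCCC#N)n1`, has not yet been measured in this assay.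

Compounds 1 and 2 share a core and differ in one place: 4-cyanobutyl in place of methoxycarbonyl)(benzyl on an aromatic nitrogen. That exchange brought a 6.6-fold higher number from compound 1 to compound 2 (0.82 log units; beyond the scatter), so the smaller chain in place of the larger group weakened binding in this pair.

Compound 3 is built from the same atoms as compound 1, joined differently; the difference between the two cores is not broken down here. Compound 3 sits at the limit of > 5000 nM in this assay, at which 1 of the 3 values shown sits, so how far it falls short of compound 1 is not known from a number.

Among the compounds with values here, the exchange planned for compound 4 is the same kind of change as the one from compound 1 to compound 2, made on the core of compound 3: 4-cyanobutyl in place of methoxycarbonyl)(benzyl on an aromatic nitrogen. The surroundings of the place are not identical in words: in compound 1 the group sits next to the ring nitrogen and next to the ring atom that bears a large group, whereas in compound 3 it sits between two ring nitrogen atoms, two ring bonds from the ring atom that bears a large group.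

Within the data shown here, since compound 3 already gives only a limit, and the one measured instance of this change weakened binding, compound 4 is expected to weaken further or stay beyond the limit, an estimated step that the limit leaves unreadable from compound 3 to compound 4. Compound 4 is therefore estimated at 20000 nM, with a likely range from 5000 nM to 100000 nM, and most probably reported only as a limit again.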

Compound 4, inhibition constant: > 5000 nM
Compound 4 was reported as a limit; the forecaster's own chance of this, stated with the estimate: 85%; the middle value does not contradict the limit.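

In this assay compound 4 gives > 5000 nM, which is a limit of the assay and not a number. Within the data shown here, compound 3 gives > 5000 nM, also a limit, so no step between compound 3 and compound 4 can be read. Both stand at the same limit: the limit of > 5000 nM in this assay, at which 2 of the 4 values shown sit.

The compounds shown leave open whether the exchange to 4-cyanobutyl changes binding on the core of compound 3 as it did on the core of compound 1.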